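Halophenyl change from compound 1 to compound 3

The source may report more compounds than this note shows. Statements on the series, on what has been measured and on what is new or still open speak of the compounds shown alone.

Compound 1 `O=C(COc1ccc(C(=O)/C=C/c2cccc(Cl)c2)cc1)N[C@H]1CCOC1=O` is assessed in a functional assay on PC-3 cells (Homo sapiens) for antiproliferative activity, read by MTT assay, with a stated time of 72 h (a higher number here means a weaker inhibitor, a lower number a stronger inhibitor), where compound 1 gives 4990 nM. Among the two measured entries of the set, this is the only numerical value. Compound 2 `O=C1OCC[C@@H]1NC(=S)SCCOc1cccc2ccccc12` returns a limit of the assay and not a number in this assay, namely > 64000 nM, which is the limit of > 64000 nM in this assay, at which 1 of the 2 values shown sits. Among the compounds with values here, no pair of measured compounds differs in a single place, so no measured step exists to calibrate the change that follows.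

Compound 3 `O=C(COc1ccc(C(=O)/C=C/c2ccccc2Br)cc1)N[C@H]1CCOC1=O` differs from compound 1 by 2-bromophenyl in place of 3-chlorophenyl on a double-bonded chain carbon bound to a double-bonded chain carbon. The shared core and the remainder of the molecule are unchanged. Without a measured step of this kind in the set, the size of the step from compound 1 to compound 3 is uncertain; the change is expected to stay close to the scatter or give a modest loss, and the expected step is a 1.4-fold higher number from compound 1 to compound 3 (0.15 log units; within the scatter). In this assay compound 3 is estimated at 7000 nM, with a range from 2500 nM to 22000 nM.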

Compound 3, half-maximal inhibitory concentration: 3260 nM
Compound 3: the middle estimate sits 2.1-fold (0.33 log units) above what was measured, and the stated range covers the measured number.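

Within the data shown here, the change from 3-chlorophenyl to 2-bromophenyl, on a double-bonded chain carbon bound to a double-bonded chain carbon, gives the first measured step in this assay: a 1.5-fold lower number from compound 1 to compound 3 (0.18 log units; within the scatter). At this place, then, the two halophenyl groups cannot be told apart in this read-out, and the swap of one for the other, with the rest of the molecule unchanged, costs no measurable activity. Nothing measured on these compounds speaks to why the two groups read alike.

The step changes the halogen and its numbered place on the phenyl ring together, so the share of each stays unresolved, and 2-chlorophenyl or 3-bromophenyl on the same carbon would be the groups that separate them. Also open, going by these compounds, is how this place responds to a phenyl carrying something other than a halogen, such as 3-aminophenyl or 3-carboxyphenyl, since a single step between two halophenyl groups says nothing beyond that pair.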